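Swapping the Sulfonyl Aryl Group: Hydroxyphenyl to Methylphenyl

This account rests on a few compounds, and the source may have more. Where it says the series, first, only, none or still open, it means among the compounds named here.

For the measured compounds named here, in a functional assay (Cavia porcellus) with sulfonylurea receptors; K-ATP channels (Homo sapiens) as the target (a lower number here means a stronger inhibitor, a higher number a weaker inhibitor), compound 2 `CC(O)(C(=O)Nc1ccc(S(=O)(=O)c2cccc(O)c2)cc1)C(F)(F)F` gives 18000 nM, the highest of the three numbers measured so far. Compound 1 `CC(O)(C(=O)Nc1ccc(S(=O)(=O)c2ccccc2)c(C#N)c1)C(F)(F)F` gives 3800 nM, and compound 3 `Cc1cc(NC(=O)C(C)(O)C(F)(F)F)ccc1S(=O)(=O)c1ccccc1` gives 1600 nM. Going by the values given here, the only measured single change, a 2.4-fold lower number from compound 1 to compound 3 (0.38 log units; beyond the scatter), alters the ring carrying the amide rather than the ring on the sulfonyl sulfur, so it does not bear directly on the present step. Compound 4 `Cc1ccccc1S(=O)(=O)c1ccc(NC(=O)C(C)(O)C(F)(F)F)cc1` differs from compound 2 by 2-methylphenyl in place of 3-hydroxyphenyl on a sulfonyl sulfur. Among the compounds with values here, no measured step covers this change; the only guide is that compound 1 and compound 3, which carry a plain phenyl on the sulfonyl sulfur, give lower numbers than compound 2. A step of a 4.5-fold lower number from compound 2 to compound 4 (0.65 log units; beyond the scatter) is therefore expected, with wide uncertainty. Compound 4 is estimated at 4000 nM, within 1000 nM to 16000 nM.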

Compound 4, half-maximal inhibitory concentration: 5100 nM
Compound 4: the middle estimate sits 1.3-fold (0.11 log units) below what was measured; the range from low to high includes it.
By their numbers in this assay, from the lowest: compound 3; then compounds 1 and 4 (each within the scatter of the next); then compound 2.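

In this assay, for the compounds shown here, this is the first measured change on the sulfonyl sulfur: a 3.5-fold lower number from compound 2 to compound 4 (0.55 log units; beyond the scatter) shows that the number responds to the aryl group held there. The step swaps 3-hydroxyphenyl, with a hydrogen-bond donor and acceptor, for 2-methylphenyl, with neither, and it also changes where the ring substituent sits, so one step cannot separate these differences. No measurement given here explains the step. Going by these compounds, how an aminophenyl or a carboxyphenyl on the sulfonyl sulfur would compare remains open.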